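The compounds below may be only part of what the source reports. "The series", "measured", "known", "first", "only" and "open" are said of these compounds alone.

Measured compounds, cytotoxicity on mouse fibroblasts:

Compound 1, `CC(=O)c1ccn(-c2ccc3c(c2)B(O)OC3)c1`. In an ADME assay on L929 cells (Mus musculus) for cytotoxicity, read by resazurin assay, with a stated time of 72 h (on this read-out lower numbers stand for stronger inhibition and higher numbers for weaker inhibition), compound 1 gives > 10 ug/mL, which is a limit of the assay and not a number.
Compound 2, `O=C(c1cccc(Cl)c1)c1ccn(-c2ccc3c(c2)B(O)OC3)c1`. In this assay compound 2 gives > 10 ug/mL, again a limit.
Compound 3, `O=C(c1ccc(O)cc1)c1ccn(-c2ccc3c(c2)B(O)OC3)c1`. In this assay compound 3 gives > 10 ug/mL, also a limit.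

For the measured compounds named here, all three values sit at the limit of > 10 ug/mL in this assay, at which 3 of the 3 values shown sit, so no compound can be ranked against another. The steps a step that the two limits leave unreadable from compound 1 to compound 2, a step that the two limits leave unreadable from compound 1 to compound 3 and a step that the two limits leave unreadable from compound 2 to compound 3 are all unreadable for the same reason: exchanging methyl for 3-chlorophenyl or 4-hydroxyphenyl on the carbonyl carbon, or one aryl for the other, produced no value that left the limit. Compound 3 therefore stands where every other compound stands, at the limit.

Compound 4, `Nc1ccc(C(=O)c2ccn(-c3ccc4c(c3)B(O)OC4)c2)cc1`, differs from compound 3 by amino in place of hydroxy on an aromatic carbon. The three measured steps bear on it only in showing that larger changes at the carbonyl carbon stayed within the limit. The step that the limit leaves unreadable from compound 3 to compound 4 is therefore expected to be none beyond the scatter. Compound 4 is estimated at 15 ug/mL, within 5 ug/mL to 50 ug/mL, most likely reported again as a limit.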

Compound 4, half-maximal inhibitory concentration: 3.9 ug/mL
Beside the measured number, compound 4's estimate is 3.8-fold (0.59 log units) above it, outside the stated range (below it).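

Amino in place of hydroxy on an aromatic carbon, para to a large group, gives an at least 2.5-fold lower number from compound 3 to compound 4 (0.40 log units; beyond the scatter), so in this assay this position responds to the exchange of a single heavy atom. The 4-aminophenyl group also reads against the other carbonyl substituents: in place of 3-chlorophenyl it gives an at least 2.5-fold lower number from compound 2 to compound 4 (0.40 log units; beyond the scatter), and in place of methyl it gives an at least 2.5-fold lower number from compound 1 to compound 4 (0.40 log units; beyond the scatter). The steps among compound 1, compound 2 and compound 3 cannot be read, because all three values are limits, which leaves 4-aminophenyl as the only group shown with a measured number: the limit of > 10 ug/mL in this assay, at which 3 of the 4 values shown sit.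

Going by these compounds, each new step has only a lower bound, so its full size stays open. On these data alone, whether a methylamino or acetamido group at this place would give a similar number also stays open.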